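Pyrazin-2-yl in place of pyrimidin-2-yl: a small swap

This account rests on a few compounds, and the source may have more. Where it says the series, first, only, none or still open, it means among the compounds named here.

In a functional assay on HeLa cells (Homo sapiens) for antiproliferative activity, read by sulforhodamine B assay (a lower number here means a stronger inhibitor, a higher number a weaker inhibitor), compound 1 `C/C(=N\Nc1nc2ccccc2o1)c1ncccn1` gives 180 nM as its reading. In this assay compound 2 `C/C(=N\Nc1nc2ccccc2o1)c1cc2ccccc2cn1` gives 100 nM as its reading, and these two values lie within the usual scatter of each other. Compound 3 `C/C(=N\N(C)c1nc2ccccc2o1)c1ccccn1` has > 50000 nM as its entry, which is a limit and not a number.

Compound 4 `C/C(=N\Nc1nc2ccccc2o1)c1cnccn1` has the same atoms as compound 1, joined differently: pyrazin-2-yl in place of pyrimidin-2-yl on a carbon with a double bond to nitrogen. For the measured compounds named here, no measured pair tests this swap directly. Compound 1 at 180 nM and compound 2 at 100 nM carry different groups on that carbon, yet their values stay within the scatter, so a large shift seems unlikely here. The expected 1.2-fold lower number from compound 1 to compound 4 (0.08 log units; within the scatter) is small, with no clear direction beyond the scatter. For compound 4 the estimated value is 150 nM with an expected range from 40 nM to 600 nM in this assay once it is measured.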

Compound 4, half-maximal inhibitory concentration: 690 nM
The estimate for compound 4 lay 4.6-fold (0.66 log units) below the measured number; measured number above the stated range.
By their numbers in this assay, from the lowest: compounds 2 and 1 (each within the scatter of the next); then compound 4. At a limit, above all of these: compound 3.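

In this assay, putting pyrazin-2-yl in place of pyrimidin-2-yl gives a 3.8-fold higher number from compound 1 to compound 4 (0.58 log units; beyond the scatter). For the compounds shown here, this is the first direct test of a change at this position, and it shows that the group on this carbon matters even when the incoming and outgoing rings have the same atoms and the same counts of hydrogen-bond donors and acceptors: how those atoms are joined is enough to move the number beyond the scatter, though only modestly. Nothing measured in the data shown accounts for this step.

Still open, from the compounds shown here alone, is whether a pyridazine ring on this carbon would give a number closer to that of pyrimidin-2-yl or pyrazin-2-yl. Also open, going by these compounds, is whether an amine or a methoxy group on the pyrazin-2-yl ring would lower or raise the number further.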